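The compounds below may be only part of what the source reports. "The series", "measured", "known", "first", "only" and "open" are said of these compounds alone.

In a functional assay on HCT-116 cells (Homo sapiens) for inhibition, read by MTT assay, with a stated time of 48 h (on this read-out higher numbers stand for weaker inhibition and lower numbers for stronger inhibition), compound 1, with the structure `O=C1CN(C2CCCC2)c2nc(Nc3ccc(N4CCCCC4)cc3)ncc2N1`, gives 4440 nM. Compound 2, with the structure `CC1CCN(c2ccc(Nc3ncc4c(n3)N(C3CCCC3)CC(=O)N4)cc2)CC1`, differs from compound 1 by methyl in place of hydrogen on a saturated ring carbon; in this assay compound 2 gives 8430 nM, and the change gave a 1.9-fold higher number from compound 1 to compound 2 (0.28 log units; within the scatter). Compound 3 has the structure `O=C1CN(C2CCCC2)c2nc(Nc3ccc(N4CCCCC4)cn3)ncc2N1`, and in this assay compound 3 gives only a limit, > 30000 nM. The difference between the cores of compound 1 and compound 3 is not broken down here. Compound 4, with the structure `CC1CCN(c2ccc(Nc3ncc4c(n3)N(C3CCCC3)CC(=O)N4)nc2)CC1`, has not yet been measured in this assay; it differs from compound 3 by methyl in place of hydrogen on a saturated ring carbon, which is the same change that turned compound 1 into compound 2, at the same place.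

Since the measured step from compound 1 to compound 2 stayed within the scatter, the step from compound 3 to compound 4 in this assay is expected to be small as well, about a step that the limit leaves unreadable from compound 3 to compound 4. Because compound 3 already sits at the limit of > 30000 nM in this assay, at which 1 of the 3 values shown sits, compound 4 is expected to give about 50000 nM in this assay, most likely again as a limit rather than a number, within a range of 25000 nM to 150000 nM.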

Compound 4, half-maximal inhibitory concentration: > 30000 nM
Compound 4 gave a limit, no number (the forecaster's own chance of this, stated with the estimate: 85%); the middle value is on the limit's open side.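

In this assay compound 4 gives > 30000 nM, which is a limit and not a number. For the compounds shown here, no step from compound 3 to compound 4 can be read, because both compounds sit at the same limit: the limit of > 30000 nM in this assay, at which 2 of the 4 values shown sit. The compounds shown leave open whether 4-methylpiperidin-1-yl in place of piperidin-1-yl changes the read-out on the core of compound 3.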